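Compound 2 to compound 3: notes on a side-chain change

The compounds below may be only part of what the source reports. "The series", "measured", "known", "first", "only" and "open" are said of these compounds alone.

Measured compounds:
- compound 1 `CN(Cc1ncc2ccccc2c1CNC(=N)N)[C@H]1CCCc2cccnc21` gives 9 L/kg
- compound 2 `CN(C)CC(=O)NCc1c(CN(C)[C@H]2CCCc3cccnc32)ncc2ccccc12` gives 1.5 L/kg

Both numbers come from an in vivo ADME assay on the whole organism for pharmacokinetics, with Rattus norvegicus as the target, at a dose of 1 mg/kg by the intravenous route (on this read-out lower numbers stand for narrower distribution and higher numbers for wider distribution into tissues), and compound 2 holds the lower of the two. Still unmeasured, compound 3 `CN(C)C(=O)NCCCc1c(CN(C)[C@H]2CCCc3cccnc32)ncc2ccccc12` carries 2-((dimethylcarbamoyl)amino)ethyl in place of (((dimethylamino)methyl)carbonyl)amino on a saturated chain carbon bound to an aromatic carbon. Going by the values given here, only one measured step is available as a guide, namely a 6.0-fold lower number from compound 1 to compound 2 (0.78 log units; beyond the scatter) on an amine nitrogen. That step is modest and involves a different pair of groups, so it sets no direction here. Among the compounds with values here, no measured step covers this exchange. The starting point therefore stays with compound 2 at 1.5 L/kg in this assay and no clear shift is expected. The estimated step is a 1.3-fold lower number from compound 2 to compound 3 (0.10 log units; within the scatter) and is expected to be small. For compound 3 the estimated value is 1.2 L/kg within an expected range of 0.5 L/kg to 3 L/kg for now.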

Compound 3, volume of distribution: 1.7 L/kg
Compound 3: the middle estimate sits 1.4-fold (0.15 log units) below what was measured; measured number inside the range.
By their numbers in this assay, from the lowest: compounds 2 and 3 (each within the scatter of the next); then compound 1.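

In this assay, placing 2-((dimethylcarbamoyl)amino)ethyl where (((dimethylamino)methyl)carbonyl)amino stood gives a 1.1-fold higher number from compound 2 to compound 3 (0.05 log units; within the scatter), so this read-out does not separate these two side chains at this position. Compound 3 also shows that the distance from compound 1 is not confined to the side chain of compound 2: a 5.3-fold lower number from compound 1 to compound 3 (0.72 log units; beyond the scatter) is, like a 6.0-fold lower number from compound 1 to compound 2 (0.78 log units; beyond the scatter), beyond the scatter. No measured evidence on the origin of either result is available here.

From the compounds shown here alone, with only these compounds, it remains open whether the lower numbers extend to other side chains or depend on features shared by those of compound 2 and compound 3. A primary amine, a carboxylic acid or a longer chain at this place would test that question.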